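The compounds below may be only part of what the source reports. "The series", "measured", "known", "first", "only" and "open" are said of these compounds alone.

Three compounds share one core and differ only in the aryl group carried on a nitrogen on an aromatic ring. In a functional assay on SK-HEP1 cells (Homo sapiens) for cytotoxicity, read by sulforhodamine B assay, with a stated time of 72 h (on this read-out lower numbers stand for stronger inhibition and higher numbers for weaker inhibition), compound 1 `CCS(=O)(=O)Nc1cc(-c2ccc3ncnc(Nc4cccc(F)c4)c3c2)cnc1OC` gives 1850 nM. In this assay compound 2 `CCS(=O)(=O)Nc1cc(-c2ccc3ncnc(Nc4ccc(F)cc4F)c3c2)cnc1OC` gives 2490 nM, and in this assay compound 3 `CCS(=O)(=O)Nc1cc(-c2ccc3ncnc(Nc4ccc(OC)cc4)c3c2)cnc1OC` gives 1610 nM. Compound 3 thus shows the lowest of the three numbers, yet the step of a 1.1-fold lower number from compound 1 to compound 3 (0.06 log units; within the scatter) and the step of a 1.5-fold lower number from compound 2 to compound 3 (0.19 log units; within the scatter) both lie within the scatter, as does the step of a 1.3-fold higher number from compound 1 to compound 2 (0.13 log units; within the scatter), so no order among the three can be read from these values.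

Compound 4 `CCS(=O)(=O)Nc1cc(-c2ccc3ncnc(Nc4ccc(Cl)c(C(=O)OC)c4)c3c2)cnc1OC` has not yet been measured in this assay. Its difference from compound 3 is 4-chloro-3-(methoxycarbonyl)phenyl in place of 4-methoxyphenyl on a nitrogen on an aromatic ring. All three measured steps concern the same kind of change, one aryl group on that nitrogen replaced by another, and none of them moved the number beyond the scatter. On that basis the step of a 1.1-fold higher number from compound 3 to compound 4 (0.05 log units; within the scatter) is expected to stay within the scatter as well, with no direction favoured. Compound 4 is therefore estimated at 1800 nM in this assay, with a range from 700 nM to 4500 nM.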

Compound 4, half-maximal inhibitory concentration: 7060 nM
The estimate for compound 4 lay 3.9-fold (0.59 log units) below the measured number; measured number above the stated range.
By their numbers in this assay, from the lowest: compounds 3, 1 and 2 (each within the scatter of the next); then compound 4.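

In this assay, the aryl group on a nitrogen on an aromatic ring proves able to move the number after all: the 4-chloro-3-(methoxycarbonyl)phenyl group gives a 4.4-fold higher number from compound 3 to compound 4 (0.64 log units; beyond the scatter), and the comparisons with the other two aryl groups give a 2.8-fold higher number from compound 2 to compound 4 (0.45 log units; beyond the scatter) and a 3.8-fold higher number from compound 1 to compound 4 (0.58 log units; beyond the scatter), each a modest step towards weaker inhibition. The earlier 3-fluorophenyl, 2,4-difluorophenyl and 4-methoxyphenyl groups stayed within the scatter of one another, so the tolerance they suggested covers those three groups only and does not extend to this one, which has 11 heavy atoms against 8 in 4-methoxyphenyl and brings a double bond outside aromatic rings. Nothing available explains why this replacement raises the number.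

The chlorine and the methoxycarbonyl group enter together, so the compounds shown cannot assign the step to either, and a phenyl carrying only the 4-chloro or only the 3-(methoxycarbonyl) substituent would be needed to separate them. From the compounds shown here alone, it also remains open how the number would respond if a carboxylic acid or a primary amide stood in place of the methyl ester.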